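Compound 2 and a longer methylpiperazinyl side chain

A few compounds are considered here, and "the series" means these few. Any claim that something is new, unique, unknown or untested is made for them only; others in the source may bear on it.

In a functional assay on A-375 cells (Homo sapiens) for cytotoxicity, read by MTT assay, with a stated time of 72 h (a lower number here means a stronger inhibitor, a higher number a weaker inhibitor), compound 1 (`O=C1c2c[n+]([O-])c3ccccc3c2C(=O)c2c1c1ccccc1n2CCN1CCCC1`) gives 430 nM and compound 2 (`O=C1c2c[n+]([O-])c3ccccc3c2C(=O)c2c1c1ccccc1n2CCN1CCCCC1`) gives 180 nM, the lower of the two numbers. Compound 3 (`CN1CCN(CCCCCCn2c3c(c4ccccc42)C(=O)c2c[n+]([O-])c4ccccc4c2C3=O)CC1`) differs from compound 2 on a saturated chain carbon, two bonds along the chain from an aromatic nitrogen: 4-(4-methylpiperazin-1-yl)butyl in place of piperidin-1-yl on a saturated chain carbon, two bonds along the chain from an aromatic nitrogen. Going by the values given here, the only measured step bearing on this, a 2.4-fold lower number from compound 1 to compound 2 (0.38 log units; beyond the scatter), is modest and exchanges one ring for another, so it gives only a loose guide to a change this large. A modest move toward a higher number is expected, a 1.7-fold higher number from compound 2 to compound 3 (0.22 log units; within the scatter). For compound 3 the estimated value is 300 nM, within an expected range of 80 nM to 1100 nM.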

Compound 3, half-maximal inhibitory concentration: 630 nM
Compound 3: middle estimate off by 2.1-fold (0.32 log units), on the low side, within the range that was stated.
By their numbers in this assay, from the lowest: compound 2; then compounds 1 and 3 (each within the scatter of the next).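

In this assay, the larger side chain gives up what piperidin-1-yl had gained, with a 3.5-fold higher number from compound 2 to compound 3 (0.54 log units; beyond the scatter) in this position. Against the pyrrolidin-1-yl compound, the same change gives a 1.5-fold higher number from compound 1 to compound 3 (0.17 log units; within the scatter) and stays within the scatter, so the position accepts 4-(4-methylpiperazin-1-yl)butyl without a step beyond the scatter from that compound. Nothing at hand explains these steps.

Chain length and ring change together here, so the share of each in the step stays open. A 4-methylpiperazin-1-yl on the short chain, or a piperidine on the longer chain, would separate them.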